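Bromo to chloro swap on the aryl ring of compound 1

The source may hold more compounds than are shown below. What is called first, only, known or untested is meant among the compounds shown, and "the series" means these compounds.

Series of isatin-derived compounds on a shared bicyclic core. Compound 2 `O=C1C(=O)N(CN2CCCCC2)c2cccc(Br)c21` gives 35300 nM in a functional assay on MDA-MB-468 cells (Homo sapiens) for cytotoxicity, read by sulforhodamine B assay, with a stated time of 48 h; a higher number here means a weaker inhibitor of growth, a lower number a stronger inhibitor of growth; compound 3 `O=C1C(=O)N(CN2CCCCC2)c2cccc(Cl)c21` gives 82800 nM there. The change between them, (chloro in place of bromo on an aromatic carbon), produced a 2.3-fold higher number from compound 2 to compound 3 (0.37 log units; beyond the scatter). Compound 1 `Cc1ccc2nc(/N=C3\C(=O)N(CN(c4ccccc4)c4ccccc4)c4cccc(Br)c43)sc2c1` gives 82300 nM in this assay, a number that sits alongside that of compound 3 and is higher than that of compound 2. The difference between the core of compound 1 and the core of compound 2 is not broken down here.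

Compound 4 `Cc1ccc2nc(/N=C3\C(=O)N(CN(c4ccccc4)c4ccccc4)c4cccc(Cl)c43)sc2c1` is not yet measured. It differs from compound 1 by chloro in place of bromo on an aromatic carbon, the same change as from compound 2 to compound 3, at a place described in the same words. For the measured compounds named here, with only that single earlier step to rest on, a comparable weakening is expected: for compound 4 the step of a 1.9-fold higher number from compound 1 to compound 4 (0.29 log units; within the scatter) is estimated, resting on the step of a 2.3-fold higher number from compound 2 to compound 3 (0.37 log units; beyond the scatter). Compound 4 is therefore expected to give about 160000 nM in this assay, with a likely range from 60000 nM to 400000 nM.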

Compound 4, concentration for 50% growth inhibition: 85000 nM
Compound 4: the middle estimate sits 1.9-fold (0.27 log units) above what was measured; the range from low to high includes it.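

In this assay, chloro in place of bromo on an aromatic carbon gives a 1.0-fold higher number from compound 1 to compound 4 (0.01 log units; within the scatter), and this step shows no change on the core of compound 1. Set beside the earlier step on the other core, the new step does not separate from it: the same change on two cores in this assay, a 2.3-fold higher number (0.37 log units; beyond the scatter) from compound 2 to compound 3 and a 1.0-fold higher number (0.01 log units; within the scatter) from compound 1 to compound 4, 2.3-fold (0.36 log units) apart, within the scatter of two such steps. The two steps are therefore compatible with a change that carries from one core to the other, but two pairs do not fix the size of the step or show that it would hold on further cores in the series.

Open, on these data alone, is how fluoro, methoxy or an amine on this same aromatic carbon would compare with chloro and bromo on either core. The cores also differ in more than one place, leaving open what each difference contributes, and how a morpholine in place of the piperidine would read in this assay.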